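The source may report more compounds than this note shows. Statements on the series, on what has been measured and on what is new or still open speak of the compounds shown alone.

Measured in a functional assay on Jurkat cells (Homo sapiens) for cytotoxicity, with a stated time of 72 h (on this read-out higher numbers stand for an effect only at larger amounts of compound and lower numbers for an effect already at smaller amounts), all three values being limits:
- compound 1 `C=C[C@@](C)(/C=C/c1ccc(O)cc1)CC/C=C/C#N`: > 49000 nM
- compound 2 `C=C[C@@](C)(/C=C/c1ccc(O)cc1)CC/C=C(C)/C=C/C(=O)OCc1ccccc1`: > 49000 nM
- compound 3 `C=C[C@@](C)(/C=C/c1ccc(O)c(CO)c1)CCC=C(C)C`: > 49000 nM

Compound 3 has only a limit, > 49000 nM, and no number in this assay. Among the compounds with values here, the series so far sits at one ceiling: the limit of > 49000 nM in this assay, at which 3 of the 3 values shown sit. Compound 4 `C=C[C@@](C)(/C=C/c1ccc(O)c(C=O)c1)CCC=C(C)C` carries formyl in place of hydroxymethyl on an aromatic carbon, ortho to a hydroxy group: formyl in place of hydroxymethyl on an aromatic carbon. Within the data shown here, no measured step gives a size for this change. Any shift could only show as a lower number, so none or a modest one is expected. The expected size, in that direction, is the estimated at least 1.6-fold lower number from compound 3 to compound 4 (0.21 log units; that floor lies within the scatter). For compound 4 the estimate is 30000 nM, with an expected range of 9000 nM to 49000 nM.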

Compound 4, half-maximal effective concentration: > 49000 nM
Compound 4 was reported as a limit (the forecaster's own chance of this, stated with the estimate: 55%); middle value at least 1.6-fold (0.21 log units) from the limit.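

Compound 3 and compound 4 are both reported only as limits, so no step can be read between them. The compounds shown leave open whether formyl in place of hydroxymethyl on an aromatic carbon changes the read-out at all, with the whole series at one ceiling: the limit of > 49000 nM in this assay, at which 4 of the 4 values shown sit.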